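A few compounds are considered here, and "the series" means these few. Any claim that something is new, unique, unknown or untested is made for them only; others in the source may bear on it.

Two esters built on the same core have been measured so far: compound 1 `COc1cc(OC)c(OC)cc1/C=C/COC(=O)/C=C/c1cc(OC)c(OC)c(OC)c1` and compound 2 `COc1cc(OC)c(OC)cc1/C=C/COC(=O)/C=C/c1cccc(Br)c1`. In a functional assay on the whole organism (strain Kunming) with Mus musculus as the target, with a stated time of 0.5 h, at a dose of 300 mg/kg by the intraperitoneal route (a lower number here means a stronger effect, a higher number a weaker effect of the compound at the dose given), compound 1 gives 75%, while compound 2 gives 50%. Compound 2 thus holds the lowest of the two numbers, and its nearest neighbour is compound 1, whose number is higher by a gap that lies beyond the scatter of the method. Going by the values given here, no pair among the measured compounds differs in a single place, so no step of known size is available.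

The next compound, compound 3 `COc1cc(OC)c(OC)cc1/C=C/COC(=O)/C=C/c1ccc(Cl)cc1`, is still to be measured. Its structure departs from compound 2 in one place: 4-chlorophenyl in place of 3-bromophenyl on a double-bonded chain carbon bound to a double-bonded chain carbon. The 3-bromophenyl leaves and the 4-chlorophenyl enters on the double-bonded chain carbon, with the rest of the molecule kept as it stands in compound 2.

Among the compounds with values here, with no comparable step recorded, the expected change from compound 2 to compound 3 is small, a number 5 percentage points higher from compound 2 to compound 3 (within the scatter), a shift estimated to fall within the scatter or only slightly toward a higher number. Compound 3 is therefore expected to give about 55% in this assay, within a range from 35% to 80%.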

Compound 3, a percentage reported as activity, at one dose (the size of the read-out at that dose, not a potency): 50%
For compound 3 the middle estimate is 5 percentage points above the measured one; the range from low to high includes it.
By their numbers in this assay, from the lowest: compounds 2 and 3 (each within the scatter of the next); then compound 1.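

In this assay, putting 4-chlorophenyl in place of 3-bromophenyl on a double-bonded chain carbon bound to a double-bonded chain carbon gives no change at the digits printed from compound 2 to compound 3 (within the scatter), the first step of known size among these esters. At this place, then, the read-out at the dose given does not separate the two halogen-bearing phenyl groups, which match in heavy-atom count and in their donor and acceptor counts. The step changes both the halogen and its ring position at once, so it cannot show what either change does alone, and nothing available here bears on why the two compounds match.

The compounds shown leave open how a 3-chlorophenyl or a 4-bromophenyl group would read at this place, which would divide the step into its two parts. They also leave open whether an unsubstituted phenyl, or a phenyl ring carrying an amine or a carboxylic acid, would stay within the scatter of compound 2 and compound 3 or move away from them.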